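Ring Swap on a Sulfonyl Group in Two Matched Pairs

This account rests on a few compounds, and the source may have more. Where it says the series, first, only, none or still open, it means among the compounds named here.

Compound 1 `COC(=O)NC(=O)c1ccsc1NC(=O)c1ccc(S(=O)(=O)N2CCCCCC2)cc1` gives 9.13 ug/mL in a toxicity assay on Vero cells (Chlorocebus sabaeus) for cytotoxicity, read by MTT assay; on this read-out higher numbers stand for weaker inhibition and lower numbers for stronger inhibition. Compound 2 `COC(=O)NC(=O)c1ccsc1NC(=O)c1ccc(S(=O)(=O)N2CCC(OC)CC2)cc1` differs from compound 1 by 4-methoxypiperidin-1-yl in place of azepan-1-yl on a sulfonyl sulfur; in this assay compound 2 gives 18 ug/mL, a step of a 2.0-fold higher number from compound 1 to compound 2 (0.29 log units; within the scatter). Compound 3 `CCOC(=O)NC(=O)c1ccsc1NC(=O)c1ccc(S(=O)(=O)N2CCCCCC2)cc1` differs from compound 1 by methyl in place of hydrogen on a saturated chain carbon bound to an oxygen next to a carbonyl group; in this assay compound 3 gives 3.42 ug/mL, a step of a 2.7-fold lower number from compound 1 to compound 3 (0.43 log units; beyond the scatter); compound 3 holds the lowest number of the three measured compounds. Compound 4 `CCOC(=O)NC(=O)c1ccsc1NC(=O)c1ccc(S(=O)(=O)N2CCC(OC)CC2)cc1` has not yet been measured. It differs from compound 3 by 4-methoxypiperidin-1-yl in place of azepan-1-yl on a sulfonyl sulfur, which is the same change that was made from compound 1 to compound 2, on the same kind of place, and the two cores differ only by the methyl described above. Since the change in the first pair gave a step within the scatter, compound 4 is expected to sit near compound 3, with an estimated step of a 1.9-fold higher number from compound 3 to compound 4 (0.28 log units; within the scatter). For compound 4 the expected value in this assay is 6.5 ug/mL, with a likely range from 3.4 ug/mL to 12.5 ug/mL.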

Compound 4, half-maximal inhibitory concentration: 21 ug/mL
For compound 4 the middle estimate is 3.2-fold (0.51 log units) below the measured one; measured number above the stated range.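

In this assay the swap of azepan-1-yl for 4-methoxypiperidin-1-yl gave a 6.1-fold higher number from compound 3 to compound 4 (0.79 log units; beyond the scatter), and this step does not match the one seen on the core of compound 1: the same change on two cores in this assay, a 2.0-fold higher number (0.29 log units; within the scatter) from compound 1 to compound 2 and a 6.1-fold higher number (0.79 log units; beyond the scatter) from compound 3 to compound 4, 3.1-fold (0.49 log units) apart, beyond the scatter of two such steps

The added methyl gave a 1.2-fold higher number from compound 2 to compound 4 (0.07 log units; within the scatter) with 4-methoxypiperidin-1-yl on the sulfonyl sulfur, so the drop it brought with azepan-1-yl did not carry over: the same change on two cores in this assay, a 2.7-fold lower number (0.43 log units; beyond the scatter) from compound 1 to compound 3 and a 1.2-fold higher number (0.07 log units; within the scatter) from compound 2 to compound 4, 3.1-fold (0.49 log units) apart, beyond the scatter of two such steps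

Across these four compounds, then, the size of each change depends on what stands at the other place, but the two comparisons rest on the same four values and count as one observation, and they show neither why this happens nor whether it extends to other groups.

The compounds shown leave open whether a plain piperidin-1-yl or a morpholine ring on the sulfonyl sulfur would follow compound 2 and compound 4 or the azepan-1-yl pair. They also leave open how a longer chain in place of the added methyl would behave on either side.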